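The source may report more compounds than this note shows. Statements on the series, on what has been measured and on what is new or still open speak of the compounds shown alone.

In a functional assay on HL-60 cells (Homo sapiens) for antiproliferative activity, read by MTT assay, with a stated time of 72 h (on this read-out higher numbers stand for weaker inhibition and lower numbers for stronger inhibition), compound 1 `COc1cc(-c2ncnn2-c2cccc(F)c2)cc(OC)c1OC` gives > 10000 nM, which is a limit of the assay and not a number. Compound 2 `COc1cc(-c2ncnn2-c2ccccc2)cc(OC)c1OC` gives > 10000 nM, also a limit, so its place in the series cannot be read as a number. Compound 3 `COc1ccc(-n2ncnc2-c2cc(OC)c(OC)c(OC)c2)cc1` differs from compound 2 by one change: methoxy in place of hydrogen on an aromatic carbon, in words phenyl to 4-methoxyphenyl. Going by the values given here, the only measured step within reach is a step that the two limits leave unreadable from compound 1 to compound 2, and it concerns fluoro, not methoxy. The measured record amounts to the limit of > 10000 nM in this assay, at which 2 of the 2 values shown sit, so no step size can be carried over from it. Methoxy has no measured precedent in this pair of compounds. Compound 3 may therefore remain at the limit, and that outcome keeps a substantial probability. If a number does appear, it is expected on the side of stronger inhibition, the only readable direction from the limit shown by compound 2. For compound 3 the estimated value is 800 nM, with an expected range of 40 nM to 10000 nM. The estimate corresponds to an expected step of an at least 12-fold lower number from compound 2 to compound 3 (1.09 log units; beyond the scatter), with wide uncertainty.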

Compound 3, half-maximal inhibitory concentration: 6200 nM
Compound 3: the middle estimate sits 7.8-fold (0.89 log units) below what was measured; measured number inside the range.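

Methoxy in place of hydrogen, on an aromatic carbon para to a large group, is the one change here that gives a number rather than a limit in this assay, with an at least 1.6-fold lower number from compound 2 to compound 3 (0.20 log units; that floor lies within the scatter). Set against the 3-fluorophenyl group on the aromatic nitrogen, 4-methoxyphenyl gives an at least 1.6-fold lower number from compound 1 to compound 3 (0.20 log units; that floor lies within the scatter). Both steps are floors that lie within the scatter, so this position is shown to admit a readable value, but the true size of the methoxy step stays unfixed, and most of the series still rests at a limit of the assay: the limit of > 10000 nM in this assay, at which 2 of the 3 values shown sit.

Going by these compounds, the step between compound 1 and compound 2 cannot be read, so whether fluoro has any bearing on this read-out remains unknown, and the reach of the methoxy result is limited to this one carbon of this one ring. On these data alone, whether methoxy is specifically needed there stays open: a hydroxyl, an amine or a longer ethoxy chain on the same carbon would show whether the value follows this group or holds for other substituents.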